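Replacing the cyclohexyl group of compound 3

The source may hold more compounds than are shown below. What is called first, only, known or untested is meant among the compounds shown, and "the series" means these compounds.

Measured in a functional assay on NUGC-3 cells (Homo sapiens) for antiproliferative activity, read by sulforhodamine B assay; on this read-out lower numbers stand for stronger inhibition of growth and higher numbers for weaker inhibition of growth:
compound 1 `CC(C)(C)CCOc1cccc(O)c1C(=O)/C=C/c1ccc(C(=O)O)cc1` gives 5440 nM
compound 2 `CC(C)(C)CCOc1cccc(O)c1C(=O)/C=C/c1ccc(O)cc1` gives 3300 nM
compound 3 `O=C(/C=C/c1ccc(O)cc1)c1c(O)cccc1OCC1CCCCC1` gives > 30000 nM

Compound 3 stands at the limit of > 30000 nM in this assay, at which 1 of the 3 values shown sits, which is a limit and not a number. Compound 4 (`CC(C)COc1cccc(O)c1C(=O)/C=C/c1ccc(O)cc1`) has isopropyl in place of cyclohexyl on a saturated chain carbon bound to an oxygen on an aromatic ring. The step that bears on this is an at least 9.0-fold higher number from compound 2 to compound 3 (0.95 log units; beyond the scatter), which brought the cyclohexyl in. Isopropyl forms no ring, like the neopentyl of compound 2 (3300 nM), so most of that step is expected to reverse. The expected change is an at least 5.0-fold lower number from compound 3 to compound 4 (0.69 log units; beyond the scatter), towards stronger inhibition of growth. Compound 4 is estimated at 6000 nM (range 2000 nM to 20000 nM).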

Compound 4, concentration for 50% growth inhibition: 2980 nM
Beside the measured number, compound 4's estimate is 2.0-fold (0.30 log units) above it, within the range that was stated.
By their numbers in this assay, from the lowest: compounds 4, 2 and 1 (each within the scatter of the next). At a limit, above all of these: compound 3.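

In this assay there is an at least 10-fold lower number from compound 3 to compound 4 (1.00 log units; beyond the scatter), so at this place an open isopropyl end keeps the growth inhibition that the cyclohexyl end lacks. The figure for compound 3 is a limit and not a number: the limit of > 30000 nM in this assay, at which 1 of the 4 values shown sits.

Isopropyl and neopentyl cannot be told apart, with a 1.1-fold lower number from compound 2 to compound 4 (0.04 log units; within the scatter), so only the cyclohexyl stands out among these three groups. On these data alone, whether a smaller ring such as cyclopropyl would behave like the cyclohexyl stays open. So does the effect of a longer straight chain or an amine at this place.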